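The source may report more compounds than this note shows. Statements on the series, on what has been measured and on what is new or still open speak of the compounds shown alone.

Compound 2 `CCNC(=S)N1N=C(c2ccc(C)cc2)CC1c1ccc[nH]1` was tested in a functional assay on the whole organism (strain Swiss Albino) for inhibition, with Mus musculus as the target, read by paw edema, with a stated time of 90 min, at a dose of 100 mg/kg by the oral route (a lower number here means less inhibition, a higher number more inhibition at the dose given (going by the name of the read-out)), where compound 2 gives 4.9%. Its closest relative, compound 1 `CNC(=S)N1N=C(c2ccc(C)cc2)CC1c1ccc[nH]1`, gives 13.2% in the same setting. On these two numbers compound 2 sits alongside compound 1: the gap between them is within the scatter of repeated measurements, so neither can be set apart from the other.

Going by the values given here, the only step measured so far is the one from compound 1 to compound 2, a number 8.3 percentage points lower from compound 1 to compound 2 (within the scatter). That step was a methyl in place of hydrogen on a saturated chain carbon bound to an amide-type nitrogen, and it moved the read-out by an amount that falls inside the scatter.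

Compound 3 `CCCNC(=S)N1N=C(c2ccc(C)cc2)CC1c1ccc[nH]1` is not yet measured. It differs from compound 2 in one place: methyl in place of hydrogen on a saturated chain carbon, two bonds along the chain from an amide-type nitrogen. This is the same kind of change as the measured step, carried one bond further out along the chain. Since the measured step did not move the read-out beyond the scatter, the expected step of a number 2.1 percentage points higher from compound 2 to compound 3 (within the scatter) is likewise none beyond the scatter. Compound 3 is therefore estimated at 7%, with a range from 0% to 20%.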

Compound 3, a percentage reported as inhibition, in the whole organism at one dose (the size of the read-out at that dose, not a potency): 14.6%
Estimate against measurement, compound 3: 7.6 percentage points below, and the stated range covers the measured number.
By their numbers in this assay, from the lowest: compounds 2, 1 and 3 (each within the scatter of the next).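

In this assay, going from ethyl to propyl gives a number 9.7 percentage points higher from compound 2 to compound 3 (within the scatter), so a methyl placed two bonds along the chain from an amide-type nitrogen, like the methyl added one bond closer in, does not shift the read-out beyond the usual scatter. The direct comparison of the methyl and propyl compounds agrees, with a number 1.4 percentage points higher from compound 1 to compound 3 (within the scatter), which means that methyl, ethyl and propyl at this position cannot be told apart and no trend with chain length can be claimed from these three compounds. No supporting evidence is available to give a reason for these small differences.

What the compounds shown leave open is whether a longer chain such as butyl, a branched group such as isopropyl, or a ring such as phenyl at the same nitrogen would produce a step that clearly exceeds the scatter. Since all three numbers come from a single dose and a single time point, they also cannot show whether these compounds would separate at other doses or times.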